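Notch reporter series: aryl swap at the saturated ring carbon

This account rests on a few compounds, and the source may have more. Where it says the series, first, only, none or still open, it means among the compounds named here.

Measured so far in an assay on HEK293 cells for inhibition of neurogenic locus notch homolog protein 1 (Homo sapiens), read by a luciferase reporter and resazurin assay, with a stated time of 16 h; on this read-out higher numbers stand for weaker inhibition and lower numbers for stronger inhibition:
compound 1 `CC1=C(C(=O)OCCC2CCN(C(=O)OC(C)(C)C)CC2)C(c2cccc(Br)c2)C2=C(CC(C)(C)CC2=O)N1` gives 2950 nM
compound 2 `CC1=C(C(=O)OCc2ccc(C(C)(C)C)cc2)C(c2cccc(Br)c2)C2=C(CC(C)(C)CC2=O)N1` gives 4270 nM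
compound 3 `CC1=C(C(=O)OCC2CCN(C(=O)OC(C)(C)C)CC2)C(c2cccc([N+](=O)[O-])c2)C2=C(CC(C)(C)CC2=O)N1` gives > 10000 nM

For compound 3 the read-out is only a limit of this assay, not a number. Of the three values shown it is the one sitting at the limit of > 10000 nM in this assay, at which 1 of the 3 values shown sits. Compound 4 `CC1=C(C(=O)OCC2CCN(C(=O)OC(C)(C)C)CC2)C(c2ccc(-c3ccccc3)cc2)C2=C(CC(C)(C)CC2=O)N1` differs from compound 3 by 4-phenylphenyl in place of 3-nitrophenyl on a saturated ring carbon. Within the data shown here, no step between two measured compounds is available to calibrate this change. Compound 1, carrying 3-bromophenyl on the same carbon with a related ester, gives 2950 nM, inside the numeric range. Compound 4 is therefore expected to come back into that range, a step of an at least 2.0-fold lower number from compound 3 to compound 4 (0.30 log units; that floor lies within the scatter) from the limit of compound 3. The estimate for compound 4 is 5000 nM, between 1500 nM and 20000 nM.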

Compound 4, half-maximal inhibitory concentration: > 10000 nM
Compound 4 ended at the assay's limit; the forecaster's own chance of this, stated with the estimate: 30%; middle value at least 2.0-fold (0.30 log units) from the limit.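

Compound 3 and compound 4 both end at a limit of the read-out, not at a number, so no step between them can be read: the limit of > 10000 nM in this assay, at which 2 of the 4 values shown sit.

The compounds shown leave open whether 4-phenylphenyl and 3-nitrophenyl on this saturated ring carbon differ at all.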